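Amide acyl ring size on the shared core

The source may hold more compounds than are shown below. What is called first, only, known or untested is meant among the compounds shown, and "the series" means these compounds.

In a functional assay on SK-BR-3 cells (Homo sapiens) for antiproliferative activity (on this read-out lower numbers stand for stronger inhibition and higher numbers for weaker inhibition), compound 1 `CO[C@@H]1[C@@H](O)[C@@H](O)[C@H](Oc2ccc3cc(NC(=O)C4CCC4)c(=O)oc3c2C)OC1(C)C` gives 220000 nM. Compound 2 `CO[C@@H]1[C@@H](O)[C@@H](O)[C@H](Oc2ccc3cc(NC(C)=O)c(=O)oc3c2C)OC1(C)C` stands only at a limit of this assay, > 900000 nM. Among the measured compounds shown here, the single measured step, an at least 4.0-fold higher number from compound 1 to compound 2 (0.61 log units; beyond the scatter), is bounded by the limit of > 900000 nM in this assay, at which 1 of the 2 values shown sits, and so marks a weakening on going from cyclobutyl to methyl. Compound 3 `CO[C@@H]1[C@@H](O)[C@@H](O)[C@H](Oc2ccc3cc(NC(=O)C4CCCC4)c(=O)oc3c2C)OC1(C)C` differs from compound 2 by cyclopentyl in place of methyl on a carbonyl carbon, which reverses that step with a ring larger than cyclobutyl. A step toward lower numbers of at least comparable size is expected, an at least 6.0-fold lower number from compound 2 to compound 3 (0.77 log units; beyond the scatter). Compound 3 is therefore estimated at 150000 nM, between 50000 nM and 600000 nM.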

Compound 3, half-maximal inhibitory concentration: 67000 nM
Compound 3: middle estimate off by 2.2-fold (0.35 log units), on the high side; the range from low to high includes it.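

In this assay, going from cyclobutyl to cyclopentyl on the carbonyl carbon gives a 3.3-fold lower number from compound 1 to compound 3 (0.52 log units; beyond the scatter), so ring size still counts among the rings themselves, which the earlier pair could not show. Compound 2 stands at a limit and not at a number, so the change from methyl to cyclopentyl, an at least 13-fold lower number from compound 2 to compound 3 (1.12 log units; beyond the scatter), is only a bound: the limit of > 900000 nM in this assay, at which 1 of the 3 values shown sits. Across these three compounds the number falls from methyl through cyclobutyl to cyclopentyl, and none goes against this order.

From the compounds shown here alone, it remains open whether cyclohexyl would continue that fall. Going by these compounds, it is also open whether an open chain such as pentyl would match cyclopentyl, or whether an amine on the ring would keep the gain.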